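The source may report more compounds than this note shows. Statements on the series, on what has been measured and on what is new or still open speak of the compounds shown alone.

Among the measured compounds shown here, in a functional assay on A549 cells (Homo sapiens) for cytotoxicity, read by MTT assay, with a stated time of 72 h (a lower number here means a stronger inhibitor, a higher number a weaker inhibitor), compound 1 `Cc1ccc(Cn2cc(/C=N/NC(=O)Nc3nc4ccc(CN5CCC(C)CC5)cc4s3)c3ccccc32)cc1` gives 2180 nM, and its one measured neighbour, compound 2 `Cc1ccc(Cn2cc(/C=N/NC(=O)Nc3nc4ccc(CN(C)C)cc4s3)c3ccccc32)cc1`, gives 1600 nM; the step of a 1.4-fold lower number from compound 1 to compound 2 (0.13 log units; within the scatter) lies within the scatter. Compound 3 `CC1CCN(Cc2ccc3nc(NC(=O)N/N=C/c4cn(Cc5ccccc5)c5ccccc45)sc3c2)CC1` differs from compound 1 by hydrogen in place of methyl on an aromatic carbon. For the measured compounds named here, no measured step touches that part of the molecule, since the only known step alters a different group. With nothing pointing to a shift beyond the scatter, compound 3 is expected to show a step estimated as a 1.1-fold higher number from compound 1 to compound 3 (0.02 log units; within the scatter). The value expected for compound 3 in this assay is 2300 nM, within a range from 900 nM to 6000 nM.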

Compound 3, half-maximal inhibitory concentration: 2340 nM
The estimate for compound 3 lay 1.0-fold (0.01 log units) below the measured number, and the stated range covers the measured number.
By their numbers in this assay, from the lowest: compounds 2, 1 and 3 (each within the scatter of the next).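

In this assay, going from 4-methylbenzyl to benzyl gives a 1.1-fold higher number from compound 1 to compound 3 (0.03 log units; within the scatter). The methyl on this aromatic carbon, para to a large group, can therefore be replaced by hydrogen with no shift beyond the scatter, which the earlier step, made at a different group, could not show. No evidence at hand bears on this result.

As far as these compounds go, whether a methoxy group, a chlorine atom or a carboxylic acid at this place would move the number beyond the scatter stays open. So does whether the same change would read alike with the dimethylamino group of compound 2.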